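Cytotoxicity series: phenyl to hydroxy on the biaryl

A few compounds are considered here, and "the series" means these few. Any claim that something is new, unique, unknown or untested is made for them only; others in the source may bear on it.

Compound 1 `CC(C)N(Cc1cccc(OCCCCCC(=O)O)c1)C(=O)c1ccc(-c2cccc(-c3ccccc3)c2)cc1` is the reference point of the series. In an ADME assay on HepG2 cells (Homo sapiens) for cytotoxicity, read by CellTiter-Glo and resazurin assay, with a stated time of 72 h (a lower number here means that less compound is needed, a higher number that more compound is needed for the effect), compound 1 gives > 26000 nM, which is a limit of the assay and not a number. Going by the values given here, compound 1 therefore stands only at a limit; the one further value shown is also a limit, as the limit of > 26000 nM in this assay, at which 2 of the 2 values shown sit, records. Among the compounds with values here, compound 2 `CC(C)N(Cc1cccc(OCCCCCC(=O)O)c1)C(=O)c1ccc(-c2cccc(OCc3ccccc3)c2)cc1` is the only measured neighbour. In this assay compound 2 gives > 26000 nM, again a limit of the assay. The step that the two limits leave unreadable from compound 1 to compound 2 is thus unreadable in size from the two limits.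

Compound 3 `CC(C)N(Cc1cccc(OCCCCCC(=O)O)c1)C(=O)c1ccc(-c2cccc(O)c2)cc1` is not yet measured. The change from compound 1 is hydroxy in place of phenyl on an aromatic carbon. Within the data shown here, the only measured step that bears on it, from compound 1 to compound 2, sits between two limits and gives no size, so no step beyond the scatter can be read in either direction in this assay. On this basis the step for compound 3 is expected as a step that the limit leaves unreadable from compound 1 to compound 3, essentially no readable move. Compound 3 is accordingly estimated at 30000 nM, with a range from 15000 nM to 60000 nM, and most likely reported again as a limit.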

Compound 3, half-maximal effective concentration: > 26000 nM
Compound 3 ended at the assay's limit; the forecaster's own chance of this, stated with the estimate: 75%; the middle value is on the limit's open side.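

No step can be read in this assay among compound 1, compound 2 and compound 3, since all three stand at the same limit of the assay: the limit of > 26000 nM in this assay, at which 3 of the 3 values shown sit.

The compounds shown leave open whether any of the three reaches a readable half-maximal effective concentration, and so how the phenyl, benzyloxy and hydroxy compounds compare.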